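This account rests on a few compounds, and the source may have more. Where it says the series, first, only, none or still open, it means among the compounds named here.

Measured compounds:
compound 1 `CC[C@@H](C)[C@H](NC(=O)c1ccc(C(CC)(CC)c2ccc(OCC(=O)C(C)(C)C)c(C)c2)n1CC)C(=O)O` — 247 nM
compound 2 `CCn1c(C(=O)N(C)CC(=O)O)ccc1C(CC)(CC)c1ccc(OCC(=O)C(C)(C)C)c(C)c1` — 25200 nM
compound 3 `CC[C@@H](C)[C@H](NC(=O)c1ccc(C(CC)(CC)c2ccc(OCC(O)C(C)(C)C)c(C)c2)n1CC)C(=O)O` — 127 nM

The three compounds were tested in a functional assay on HepG2 cells (Homo sapiens), read by MTT assay, with a stated time of 48 h; a higher number here means a weaker inhibitor, a lower number a stronger inhibitor. Compound 1 is the reference point. Two changes were made to it. The first, ((carboxymethyl)(methyl)amino in place of (1-carboxy-2-methylbutyl)amino on a carbonyl carbon), gave a 100-fold higher number from compound 1 to compound 2 (2.01 log units; beyond the scatter). The second, (1-hydroxy-2,2-dimethylpropyl in place of (tert-butyl)carbonyl on a saturated chain carbon bound to an oxygen on an aromatic ring), gave a 1.9-fold lower number from compound 1 to compound 3 (0.29 log units; within the scatter); compound 3 and compound 1 therefore sit within the scatter of each other, while compound 2 lies well apart from both.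

Compound 4 `CCn1c(C(=O)N(C)CC(=O)O)ccc1C(CC)(CC)c1ccc(OCC(O)C(C)(C)C)c(C)c1` has not been measured in this assay. It differs from compound 3 by (carboxymethyl)(methyl)amino in place of (1-carboxy-2-methylbutyl)amino on a carbonyl carbon. Going by the values given here, this is the same change as the one from compound 1 to compound 2: the group that leaves, the group that enters and the place are the same word for word in both pairs. The two cores differ only by the change (1-hydroxy-2,2-dimethylpropyl in place of (tert-butyl)carbonyl on a saturated chain carbon bound to an oxygen on an aromatic ring), and that change lay within the scatter when it was measured.

Among the compounds with values here, for compound 4 the step from compound 3 is expected to be about as large as the earlier one, a 100-fold higher number from compound 3 to compound 4 (2.00 log units; beyond the scatter), because a 100-fold higher number from compound 1 to compound 2 (2.01 log units; beyond the scatter) is the only measurement of this change and the core difference is small. Since compound 3 gives 127 nM, compound 4 is expected to give 12700 nM, estimated to lie between 4000 nM and 40000 nM.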

Compound 4, half-maximal inhibitory concentration: 17100 nM
For compound 4 the middle estimate is 1.3-fold (0.13 log units) below the measured one, and the stated range covers the measured number.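

In this assay, (carboxymethyl)(methyl)amino in place of (1-carboxy-2-methylbutyl)amino on a carbonyl carbon gave a 130-fold higher number from compound 3 to compound 4 (2.13 log units; beyond the scatter), and the change carried from one core to the other without a difference that can be told apart: the same change on two cores in this assay, a 100-fold higher number (2.01 log units; beyond the scatter) from compound 1 to compound 2 and a 130-fold higher number (2.13 log units; beyond the scatter) from compound 3 to compound 4, 1.3-fold (0.12 log units) apart, within the scatter of two such steps. The change from (tert-butyl)carbonyl to 1-hydroxy-2,2-dimethylpropyl gave a 1.5-fold lower number from compound 2 to compound 4 (0.17 log units; within the scatter), so it also read alike on both sides of the series: the same change on two cores in this assay, a 1.9-fold lower number (0.29 log units; within the scatter) from compound 1 to compound 3 and a 1.5-fold lower number (0.17 log units; within the scatter) from compound 2 to compound 4, 1.3-fold (0.12 log units) apart, within the scatter of two such steps. Together these four compounds show that the two changes behaved independently of each other here, but they rest on a single pair of closely related cores and do not show that the large step would carry over to a core that differs elsewhere.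

The compounds shown leave open which part of the exchange accounts for the large step, as the amide hydrogen, the side chain and the two defined stereocentres all change at once. A (carboxymethyl)amino group would separate the methyl on the nitrogen from the loss of the side chain, and a methyl ester in place of the carboxylic acid would ask whether the acid itself matters on either core.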